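Swapping an Ether Side Chain for a Plain Hydrocarbon Chain

The compounds below may be only part of what the source reports. "The series", "measured", "known", "first", "only" and "open" are said of these compounds alone.

Two compounds that share a common core carrying a trimethoxybenzyl group have been tested in a functional assay on MCF7 cells (Homo sapiens) for antiproliferative activity; a lower number here means a stronger inhibitor, a higher number a weaker inhibitor. Compound 1, `COc1cc(Cc2nc3c(N)ncnc3n2CCOC(C)C)cc(OC)c1OC`, gives 38900 nM in this assay. Compound 2, `C#CCCn1c(Cc2cc(OC)c(OC)c(OC)c2)nc2c(N)nc(F)nc21`, gives 25100 nM in this assay. Compound 1 has the higher of the two numbers, but the gap to compound 2 lies within the scatter of repeated measurements, so the two cannot be told apart. Both are weak inhibitors.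

Compound 3, `CCC(C)Cn1c(Cc2cc(OC)c(OC)c(OC)c2)nc2c(N)ncnc21`, has not yet been measured. It differs from compound 1 in one place: sec-butyl in place of isopropoxymethyl on a saturated chain carbon bound to an aromatic nitrogen. Among the measured compounds shown here, there is no measured pair here that isolates this kind of change, so its effect is unknown. The expected 1.3-fold lower number from compound 1 to compound 3 (0.11 log units; within the scatter) is none beyond the scatter, in either direction. On that basis compound 3 is estimated at about 30000 nM, within a range from 9000 nM to 100000 nM.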

Compound 3, half-maximal inhibitory concentration: 61700 nM
The estimate for compound 3 lay 2.1-fold (0.31 log units) below the measured number; low and high end bracket the measured number.
By their numbers in this assay, from the lowest: compounds 2, 1 and 3 (each within the scatter of the next, the first and the last beyond it).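

In this assay, putting sec-butyl in place of isopropoxymethyl on a saturated chain carbon bound to an aromatic nitrogen gives a 1.6-fold higher number from compound 1 to compound 3 (0.20 log units; within the scatter) and so leaves the two compounds indistinguishable. Among the compounds shown here, this pair is the first to isolate this swap, and it shows that an all-carbon chain and a chain holding an ether oxygen cannot be told apart here, with both compounds remaining weak inhibitors. Nothing measured alongside these compounds bears on why the two chains read alike.

Going by these compounds, what an amine, a carboxylic acid or a longer chain would do at this position remains open. Also unsettled is whether any group placed here on the shared core could give a clearly stronger inhibitor than these two.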